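Fluoro to Methylsulfanyl on the Shared Core

A few compounds are considered here, and "the series" means these few. Any claim that something is new, unique, unknown or untested is made for them only; others in the source may bear on it.

Compound 1 `CN1CCN(C(=O)c2cnc(C(=O)CCCCCCc3ccccc3)o2)CC1`: 80 nM
Compound 2 `O=C(CCCCCCc1ccccc1)c1ncc(F)o1`: 30 nM

In an assay (Rattus norvegicus) for inhibition of Fatty-acid amide hydrolase 1 (Homo sapiens) (on this read-out lower numbers stand for stronger inhibition and higher numbers for weaker inhibition), compound 2 gives the lowest of the two numbers, with compound 1 a step above it: a 2.7-fold lower number from compound 1 to compound 2 (0.43 log units; beyond the scatter). Compound 3 `CSc1cnc(C(=O)CCCCCCc2ccccc2)o1` differs from compound 2 in one place: methylsulfanyl in place of fluoro on an aromatic carbon. Going by the values given here, no measured step swaps one small group for another at this position; the only step known changes this position and is modest. A small move, if any, is therefore expected for compound 3 in this assay, a 1.3-fold higher number from compound 2 to compound 3 (0.12 log units; within the scatter). Compound 3 is estimated at 40 nM, within 15 nM to 120 nM.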

Compound 3, inhibition constant: 25 nM
The estimate for compound 3 lay 1.6-fold (0.20 log units) above the measured number, within the range that was stated.
By their numbers in this assay, from the lowest: compounds 3 and 2 (each within the scatter of the next); then compound 1.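

In this assay the change from fluoro to methylsulfanyl gives a 1.2-fold lower number from compound 2 to compound 3 (0.08 log units; within the scatter) and so shows that this position tolerates either small group about equally. The comparison with the larger group gives a 3.2-fold lower number from compound 1 to compound 3 (0.51 log units; beyond the scatter) and shows that a second small group also sits apart from the (4-methylpiperazin-1-yl)carbonyl of compound 1. Nothing at hand explains these results.

On these data alone, whether a plain hydrogen, an amine or a carboxylic acid would fit this position equally well stays open. So does the effect of a longer chain on the sulfur.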